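Swapping Chloro for Methoxy on Compound 1

The source may report more compounds than this note shows. Statements on the series, on what has been measured and on what is new or still open speak of the compounds shown alone.

Measured so far:
Compound 1, `Nc1cccc(-c2cn3nc(Cc4ccc(Cl)cc4)sc3n2)c1`, gives 16000 nM
Compound 2, `C=C(Br)C(=O)Nc1cccc(-c2cn3nc(Cc4ccc(Cl)cc4)sc3n2)c1`, gives 2300 nM
Compound 3, `C=C(Br)C(=O)Nc1cccc(-c2cn3nc(-c4ccc(F)cc4)sc3n2)c1`, gives 250 nM

In a functional assay on L1210 cells (Mus musculus) for inhibition, read by cell counting, with a stated time of 2 days (a higher number here means a weaker inhibitor, a lower number a stronger inhibitor), compound 1 stands highest of the three numbers. Compound 2 sits a 7.0-fold lower number from compound 1 to compound 2 (0.84 log units; beyond the scatter), and compound 3 lower still, a 9.2-fold lower number from compound 2 to compound 3 (0.96 log units; beyond the scatter). Compound 4, `COc1ccc(Cc2nn3cc(-c4cccc(N)c4)nc3s2)cc1`, differs from compound 1 in one place: methoxy in place of chloro on an aromatic carbon. Neither measured step makes this kind of change; one adds a (1-bromoethenyl)carbonyl to a nitrogen, the other replaces 4-chlorobenzyl with 4-fluorophenyl, so they offer no direct guide to size or direction here. In this assay I therefore expect a step for compound 4 that stays within the scatter, no change at the digits printed from compound 1 to compound 4 (within the scatter). Compound 4 is estimated at 16000 nM, between 6000 nM and 40000 nM.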

Compound 4, half-maximal inhibitory concentration: 227000 nM
Compound 4: the middle estimate sits 14-fold (1.15 log units) below what was measured, outside the stated range (above it).
By their numbers in this assay, from the lowest: compound 3; then compound 2; then compound 1; then compound 4.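

In this assay, changing 4-chlorophenyl to 4-methoxyphenyl gives a 14-fold higher number from compound 1 to compound 4 (1.15 log units; beyond the scatter). For the compounds shown here, the earlier steps never altered the chloro alone, so this is the first sign that a swap of one small group at this ring carbon can by itself weaken inhibition markedly. Nothing available explains this loss.

Still open, going by these compounds, is whether a fluoro, methyl or hydroxyl group here would stay close to compound 1 or behave like compound 4. Also open, on these data alone, is whether methoxy would have the same effect in compound 2, which carries the (1-bromoethenyl)carbonyl group.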